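Aryl exchange in a series held at an assay limit

The compounds below may be only part of what the source reports. "The series", "measured", "known", "first", "only" and "open" are said of these compounds alone.

Compound 1 `N#Cc1ccc(NCCNc2ncc(-c3ncc[nH]3)c(-c3ccc(Cl)cc3Cl)n2)nc1` half-life > 0.5 h (limit)
Compound 2 `Nc1nc(NCCNc2ncc(-c3ncc[nH]3)c(-c3ccccc3Cl)n2)ccc1[N+](=O)[O-]` half-life > 0.5 h (limit)

In an ADME assay on microsomes from liver (Rattus norvegicus) for metabolic stability (a lower number here means that the compound disappears faster, a higher number that the compound lasts longer), compound 2 reads > 0.5 h and this is a limit of the assay, not a number. Compound 1 likewise reads > 0.5 h and this too is only a limit. The whole picture so far is the limit of > 0.5 h in this assay, at which 2 of the 2 values shown sit, and no numerical half-life is available for either compound. Within the data shown here, no measured step exists, so nothing yet shows how far a change of aryl group moves the read-out.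

Compound 3 `Nc1nc(NCCNc2ncc(-c3ncc[nH]3)c(-c3cc(F)c(F)cc3F)n2)ccc1[N+](=O)[O-]` carries one change relative to compound 2: 2,4,5-trifluorophenyl in place of 2-chlorophenyl on an aromatic carbon with 2,4,5-trifluorophenyl in place of 2-chlorophenyl on an aromatic carbon of the shared core. The expectation rests on compound 2 with its limit of > 0.5 h and on nothing measured for this change itself. The expected move is a step that the limit leaves unreadable from compound 2 to compound 3 and this estimate stays within the usual scatter of this assay with no firm direction. Compound 3 is estimated at 0.7 h within an expected range of 0.35 h to 1.5 h and may well turn out as a limit again.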

Compound 3, half-life: > 0.5 h
Compound 3 gave a limit, no number; the forecaster's own chance of this, stated with the estimate: 65%; the middle value does not contradict the limit.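

No step can be read between compound 2 and compound 3, the exchange of 2-chlorophenyl for 2,4,5-trifluorophenyl, because both compounds sit at the same limit of the assay: the limit of > 0.5 h in this assay, at which 3 of the 3 values shown sit.

Left open is how long any of the three compounds actually lasts in this assay and whether this aryl exchange moves the half-life at all.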